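From 4-ethylphenyl to thiophen-2-yl on a shared core

The compounds below may be only part of what the source reports. "The series", "measured", "known", "first", "only" and "open" are said of these compounds alone.

Four compounds share one core and differ in the group on a double-bonded chain carbon bound to a double-bonded chain carbon: compound 1 (`COC1=C(C)C(=O)/C(=C(O)/C=C/c2ccccc2OC)C(=O)C1(C)C`), compound 2 (`COC1=C(C)C(=O)/C(=C(O)/C=C/c2ccc(F)cc2)C(=O)C1(C)C`), compound 3 (`CCc1ccc(/C=C/C(O)=C2/C(=O)C(C)=C(OC)C(C)(C)C2=O)cc1`) and compound 4 (`COC1=C(C)C(=O)/C(=C(O)/C=C/c2cccs2)C(=O)C1(C)C`). In a functional assay on 1A9 cells (Homo sapiens) for cytotoxicity (on this read-out lower numbers stand for an effect already at smaller amounts and higher numbers for an effect only at larger amounts of compound), compound 3 gives 5.3 ug/mL as the higher of the two numbers available, and compound 1 gives 2.5 ug/mL as the lower. Compound 2 stands at "not determined" (no result reported) and so adds no number. The change followed here is thiophen-2-yl in place of 4-ethylphenyl on a double-bonded chain carbon bound to a double-bonded chain carbon and it leads to compound 4, which has not yet been measured. Within the data shown here, only one measured step bears on it: a 2.1-fold higher number from compound 1 to compound 3 (0.33 log units; beyond the scatter) at the same place, modest in size. Among the measured compounds shown here, no measured compound carries thiophen-2-yl, so that step shows only how far one exchange at this place has moved the number. With compound 3 at 5.3 ug/mL as the upper number, a small move toward lower numbers is expected, not beyond the scatter. The estimated change is a 1.5-fold lower number from compound 3 to compound 4 (0.18 log units; within the scatter) and it is expected to stay within the usual scatter. Compound 4 is expected at 3.5 ug/mL with an estimated range from 1.5 ug/mL to 8 ug/mL in this assay when tested.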

Compound 4, concentration for half-maximal effect: 4 ug/mL
Compound 4: middle estimate off by 1.1-fold (0.06 log units), on the low side; the measured number falls inside the stated range.
By their numbers in this assay, from the lowest: compounds 1, 4 and 3 (each within the scatter of the next, the first and the last beyond it).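

In this assay, thiophen-2-yl in place of 4-ethylphenyl gives a 1.3-fold lower number from compound 3 to compound 4 (0.12 log units; within the scatter), and thiophen-2-yl in place of 2-methoxyphenyl gives a 1.6-fold higher number from compound 1 to compound 4 (0.20 log units; within the scatter). Among these compounds, the earlier compounds offered only six-membered aromatic rings of carbon at this place, and their one step, a 2.1-fold higher number from compound 1 to compound 3 (0.33 log units; beyond the scatter), lay beyond the scatter; the five-membered aromatic ring with a sulfur hetero atom now falls within the scatter of both, so the new number does not separate it from either group, even with 5 heavy atoms entering for the 8 of 4-ethylphenyl. Nothing available here gives a reason for these numbers, so the result stands as a description only.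

The group of compound 2 still has no number, so it cannot yet be placed against the other three groups on the double-bonded chain carbon. Every group with a number here is an aromatic ring, which leaves open whether an amine, a carboxylic acid or a longer alkyl chain at the same place would keep the number close to those of these compounds or move it well beyond the scatter.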